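Ortho-methyl on the anilino group of compound 3

This account rests on a few compounds, and the source may have more. Where it says the series, first, only, none or still open, it means among the compounds named here.

Compound 3 `FC(F)(F)c1ccc(CSc2nc(Nc3ccccc3)c3ccccc3n2)cc1` carries an anilino group on the shared core. In a functional assay on MGC-803 cells (Homo sapiens) for cytotoxicity, read by MTT assay, with a stated time of 72 h (on this read-out lower numbers stand for stronger inhibition and higher numbers for weaker inhibition), compound 3 gives 22200 nM, the highest of the two numbers shown. Its nearest neighbour, compound 1 `CCCCCCNc1nc(SCc2ccc(C(F)(F)F)cc2)nc2ccccc12`, gives 13100 nM in this assay, and the step of a 1.7-fold higher number from compound 1 to compound 3 (0.23 log units; within the scatter) lies within the scatter. Compound 2 `CCCCCCCCCCCCCCNc1nc(SCc2ccc(C(F)(F)F)cc2)nc2ccccc12` returns only a limit of this assay, > 50000 nM, which corresponds to the limit of > 50000 nM in this assay, at which 1 of the 3 values shown sits. The step of an at least 3.8-fold higher number from compound 1 to compound 2 (0.58 log units; beyond the scatter) shows that a longer chain on the nitrogen weakens inhibition.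

Compound 4 `Cc1ccccc1Nc1nc(SCc2ccc(C(F)(F)F)cc2)nc2ccccc12` differs from compound 3 by methyl in place of hydrogen on an aromatic carbon. No measured step touches the aromatic ring on this nitrogen; the two steps shown change only what sits on the nitrogen itself, one within the scatter and one beyond it. A single methyl is a small addition compared with either, so compound 4 is expected to stay close to compound 3, the expected step being a 1.2-fold lower number from compound 3 to compound 4 (0.09 log units; within the scatter), not beyond the scatter in either direction. Compound 4 is therefore estimated at 18000 nM in this assay, in the range 7000 nM to 45000 nM.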

Compound 4, half-maximal inhibitory concentration: 24400 nM
Beside the measured number, compound 4's estimate is 1.4-fold (0.13 log units) below it; measured number inside the range.
By their numbers in this assay, from the lowest: compounds 1, 3 and 4 (each within the scatter of the next). At a limit, above all of these: compound 2.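

In this assay, this is the first change shown on the aromatic ring of the anilino group rather than on the nitrogen itself, and the step is a 1.1-fold higher number from compound 3 to compound 4 (0.04 log units; within the scatter). Methyl in place of hydrogen on this carbon, ortho to a large group, therefore does not separate the two compounds. The step of a 1.9-fold higher number from compound 1 to compound 4 (0.27 log units; within the scatter) adds that hexyl, phenyl and 2-methylphenyl on the nitrogen all stay within the scatter of one another, and nothing at hand bears on why this methyl leaves no measurable difference.

The compounds shown leave open how a group other than methyl, such as chlorine, methoxy, an amine or a carboxylic acid, would read on this carbon. They also leave open how methyl itself would read elsewhere on this ring.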